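Aryl swap at the triazole: compound 3 to compound 4

This account rests on a few compounds, and the source may have more. Where it says the series, first, only, none or still open, it means among the compounds named here.

In a functional assay on HL-60 cells (Homo sapiens) for cytotoxicity, read by MTT assay, with a stated time of 4 days (on this read-out higher numbers stand for weaker inhibition and lower numbers for stronger inhibition), compound 1 `C=C1C(=O)[C@]23C[C@@]1(O)CC[C@H]2c1ccc(OS(=O)(=O)c2ccc(C)cc2)c(C)c1[C@@H]3Cn1cc(-c2ccccn2)nn1` gives 1810 nM. Compound 2 `Cc1c(O)ccc2c1[C@H](Cn1cc(-c3ccc(F)cc3)nn1)[C@@]13CC(=O)[C@@](C)(CC[C@@H]21)C3` returns only a limit in this assay, namely > 20000 nM. Compound 3 `C=C1C[C@]23C[C@@]1(O)CC[C@@H]2c1cccc(C)c1[C@@H]3Cn1cc(-c2ccc(OC)cc2)nn1` likewise returns only a limit in this assay, namely > 20000 nM. Compound 3 thus stands at the limit of > 20000 nM in this assay, at which 2 of the 3 values shown sit, and has no number of its own. Compound 4 `C=C1C[C@]23C[C@@]1(O)CC[C@@H]2c1cccc(C)c1[C@@H]3Cn1cc(-c2ccc(C(F)(F)F)cc2)nn1` keeps the core of compound 3 and alters only the aryl on the triazole: trifluoromethyl in place of methoxy on an aromatic carbon. Within the data shown here, no measured pair follows this change, and with compound 3 at a limit the step cannot be read from the data. The expected step is a step that the limit leaves unreadable from compound 3 to compound 4, none beyond the usual scatter. Compound 4 is estimated at 25000 nM, between 8000 nM and 60000 nM, most probably again reported as a limit.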

Compound 4, half-maximal inhibitory concentration: > 20000 nM
Compound 4: no number, only a limit; the forecaster's own chance of this, stated with the estimate: 75%; the middle value is on the limit's open side.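

Compound 3 and compound 4 both return only limits, so no step between them can be read: the limit of > 20000 nM in this assay, at which 3 of the 4 values shown sit.

From the compounds shown here alone, whether trifluoromethyl in place of methoxy changes the activity of this core at all remains open.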